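Changing the group on an amine nitrogen

A few compounds are considered here, and "the series" means these few. Any claim that something is new, unique, unknown or untested is made for them only; others in the source may bear on it.

In a functional assay on HepG2 cells (Homo sapiens) for inhibition, read by MTT assay, with a stated time of 48 h (a higher number here means a weaker inhibitor, a lower number a stronger inhibitor), compound 1 `CCOC(=O)C1=C(N/C=N/c2cccnc2Cl)Nc2[nH]nc(C)c2C1c1ccc(N(C)C)cc1` gives 4890 nM as its result, and compound 2 `CCOC(=O)C1=C(N/N=C(/Cl)c2ccc([N+](=O)[O-])cc2)Nc2[nH]nc(C)c2C1c1ccc(N(C)C)cc1` gives 55500 nM as the higher and so weaker number of the two. For the measured compounds named here, the only measured step is an 11-fold higher number from compound 1 to compound 2 (1.05 log units; beyond the scatter) and it is large, with a bigger group entering on an amine nitrogen. Going by the values given here, compound 3 `CCOC(=O)C1=C(N/N=C(/Br)c2ccccc2)Nc2[nH]nc(C)c2C1c1ccc(N(C)C)cc1` is not yet measured, and it differs from compound 2 by a group of 9 heavy atoms (7 carbon, 1 nitrogen, 1 bromine; one six-membered aromatic ring of carbon only) in place of a group of 12 heavy atoms (7 carbon, 2 nitrogen, 2 oxygen, 1 chlorine; one six-membered aromatic ring of carbon only), on an amine nitrogen as its single change. This is not a simple reversal of the measured step, so that step guides the expectation only loosely. The smaller entering group still suggests a partial return toward a lower number, given the size of an 11-fold higher number from compound 1 to compound 2 (1.05 log units; beyond the scatter) in the same direction reversed. The expected change is a 2.8-fold lower number from compound 2 to compound 3 (0.44 log units; beyond the scatter) in this assay as a rough estimate. Compound 3 is expected to give about 20000 nM with an estimated range from 6000 nM to 60000 nM as its limits.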

Compound 3, half-maximal inhibitory concentration: 72000 nM
The estimate for compound 3 lay 3.6-fold (0.56 log units) below the measured number; the measured number lies above the stated range.
By their numbers in this assay, from the lowest: compound 1; then compounds 2 and 3 (each within the scatter of the next).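

In this assay, the step of a 1.3-fold higher number from compound 2 to compound 3 (0.11 log units; within the scatter) shows that at this amine nitrogen, a group of 9 heavy atoms with bromine cannot be told apart from a group of 12 heavy atoms with chlorine. The size of the group alone therefore does not track the result, and the step of a 15-fold higher number from compound 1 to compound 3 (1.17 log units; beyond the scatter) makes the same point, since the groups exchanged there both have 9 heavy atoms, one with an aromatic ring of carbon only and the other with a ring holding 1 hetero atom. Nothing measured here explains this difference.

Which feature of the group in compound 1 goes with its lower number remains open, as its ring and its chain both differ from those in compound 3. Also open, as far as these compounds go, is how a carboxylic acid or an amine on the aromatic ring would read.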